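The source may report more compounds than this note shows. Statements on the series, on what has been measured and on what is new or still open speak of the compounds shown alone.

Of the compounds shown here, two of a shared core have been measured in a functional assay on BT-549 cells (Homo sapiens) for inhibition, read by sulforhodamine B assay, with a stated time of 48 h; a higher number here means a weaker inhibitor of growth, a lower number a stronger inhibitor of growth. Compound 1 `O=C(Nc1cccc(-n2cc(-c3ccncc3)c(-c3ccc(Cl)c(O)c3)n2)c1)Nc1cccc(C(F)(F)F)c1` gives 6510 nM in this assay. Compound 2 `COc1cc(-c2nn(-c3cccc(NC(=O)Nc4ccc(Cl)c(Cl)c4)c3)cc2-c2ccncc2)ccc1Cl` gives 1680 nM in this assay, and on the two numbers available compound 2 stands with the lower number, its separation from compound 1 lying beyond the scatter. Among the measured compounds shown here, the two compounds differ in more than one place, so no single step between them is recorded; only their two values can be compared.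

Compound 3 `O=C(Nc1cccc(-n2cc(-c3ccncc3)c(-c3ccc(Cl)c(O)c3)n2)c1)Nc1ccc(Cl)c(Cl)c1` has not yet been measured. It differs from compound 2 by hydrogen in place of methyl on an oxygen on an aromatic ring, while keeping the dichlorophenyl urea of compound 2. Compound 1, which already carries the hydroxy group, gives 6510 nM in this assay, but since its urea part also differs, that number alone does not fix the size of the present change.

The step from compound 2 to compound 3 is expected to be modest and toward a higher number, a 1.7-fold higher number from compound 2 to compound 3 (0.22 log units; within the scatter), with a fair chance it stays within the scatter. Compound 3 is therefore estimated to give 2800 nM in this assay, with a range from 900 nM to 9000 nM.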

Compound 3, concentration for 50% growth inhibition: 1700 nM
Compound 3: the middle estimate sits 1.6-fold (0.22 log units) above what was measured; the measured number falls inside the stated range.
By their numbers in this assay, from the lowest: compounds 2 and 3 (each within the scatter of the next); then compound 1.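

In this assay, hydrogen in place of methyl on an oxygen on an aromatic ring, with the dichlorophenyl urea held fixed, gives a 1.0-fold higher number from compound 2 to compound 3 (0.01 log units; within the scatter), so in this setting the methoxy and hydroxy forms cannot be told apart. Among the compounds shown here, the comparison of compound 1 with compound 2 could not separate this change from the change in the urea part, but compound 3 now allows that: with the 4-chloro-3-hydroxyphenyl group held fixed, 3,4-dichlorophenyl in place of 3-(trifluoromethyl)phenyl on an amide-type nitrogen gives a 3.8-fold lower number from compound 1 to compound 3 (0.58 log units; beyond the scatter), the only one of the two steps beyond the scatter. Nothing given here accounts for the size of either step.

From the compounds shown here alone, it remains open whether an ethoxy group or an amine at this place on the aromatic ring would also stay within the scatter, and whether methoxy and hydroxy would still match with the 3-(trifluoromethyl)phenyl urea. Going by these compounds, it is also open how other groups on the urea's phenyl ring, such as a nitrile or a carboxylic acid, would compare with 3,4-dichlorophenyl.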